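The source may report more compounds than this note shows. Statements on the series, on what has been measured and on what is new or still open speak of the compounds shown alone.

In a functional assay on HeLa cells (Homo sapiens) for cytotoxicity, read by MTT assay, with a stated time of 72 h, tested at 1 uM (a higher number here means more inhibition of growth at the concentration tested, a lower number less inhibition of growth), compound 1 `N/C(=N\NC(=S)N1CCCCCC1)c1ccccn1` gives 21.3%, the second highest of the three numbers available. Compound 2 `N/C(=N\NC(=S)N1CCOCC1)c1ccccn1` gives 12.7%, a number within the scatter of compound 1, while compound 3 `Cc1ccnc(/C(N)=N/NC(=S)N2CCCCCC2)c1` gives 43.2%. Compound 4 `Cc1cccc(/C(N)=N/NC(=S)N2CCCCCC2)n1` differs from compound 1 by methyl in place of hydrogen on an aromatic carbon. Among the compounds with values here, the one measured step that bears on this change is a number 21.9 percentage points higher from compound 1 to compound 3 (beyond the scatter), where a methyl enters the same ring at a different place. Within the data shown here, no measured step puts a methyl at the place taken in compound 4, so both direction and size remain uncertain. Compound 4 is therefore expected to give 30%, between 12% and 50%. The expected step is a number 8.7 percentage points higher from compound 1 to compound 4 (within the scatter), a modest rise carrying a wide range.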

Compound 4, percent growth inhibition at one concentration: 49.5%
Compound 4: middle estimate off by 19.5 percentage points, on the low side; the measured number falls inside the stated range.
By their numbers in this assay, from the lowest: compounds 2 and 1 (each within the scatter of the next); then compounds 3 and 4 (each within the scatter of the next).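

Methyl in place of hydrogen next to the ring nitrogen brings a number 28.2 percentage points higher from compound 1 to compound 4 (beyond the scatter) in this assay, so a rise now stands at this place as well as at the place taken in compound 3. Compound 3 gives 43.2% and compound 4 gives 49.5% and these lie within the scatter of each other, so the two places cannot be told apart here. Nothing at hand gives a reason for the rise. As far as these compounds go, whether an ethyl or a methoxy group at this place would give a like number stays open, as does whether methyl brings a like rise on the core of compound 2.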